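Fluoro to methyl on the aryl ketone ester

This account rests on a few compounds, and the source may have more. Where it says the series, first, only, none or still open, it means among the compounds named here.

Measured so far:
compound 1 `CC(Cn1cnc2c1c(=O)n(C)c(=O)n2C)OC(=O)CC(=O)c1ccc(F)cc1`: 83.8%
compound 2 `COC(C(=O)OC(C)Cn1cnc2c1c(=O)n(C)c(=O)n2C)c1ccc2ccccc2c1`: 83.7%
compound 3 `CC(Cn1cnc2c1c(=O)n(C)c(=O)n2C)OC(=O)Sc1ccccc1`: 69.9%

Three esters sharing the core of compound 1 have been run in a functional assay on MCF7 cells (Homo sapiens) for antiproliferative activity, read by MTT assay, with a stated time of 72 h, tested at 100 uM; on this read-out higher numbers stand for a weaker effect at the one concentration tested and lower numbers for a stronger effect. Compound 1 gives 83.8%, the highest of the three numbers. Within the scatter of compound 1 sits compound 2 with 83.7%, so no order between these two can be read. Compound 3 gives 69.9%. Its gap to compound 1 lies beyond the scatter, the only spread in this set that counts as real. No pair of these compounds differs in a single place, so none of the gaps can be tied to one structural change.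

Compound 4 `Cc1ccc(C(=O)CC(=O)OC(C)Cn2cnc3c2c(=O)n(C)c(=O)n3C)cc1` is the next candidate. It differs from compound 1 in one place: methyl in place of fluoro on an aromatic carbon. The group leaving and the group entering are each a single heavy atom, no ring, no donor or acceptor, and the place on the six-membered aromatic ring of carbon only is unchanged.

With no measured step of this kind in the series, the expected step is none beyond the scatter, in either direction, so the estimate for compound 4 is 82% with a range of 70% to 94%. That expectation amounts to a step of a number 1.8 percentage points lower from compound 1 to compound 4 (within the scatter).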

Compound 4, a percentage reported as activity, at one concentration (the size of the read-out at that concentration, not a potency): 86.6%
Compound 4: the middle estimate sits 4.6 percentage points below what was measured; low and high end bracket the measured number.
By their numbers in this assay, from the lowest: compound 3; then compounds 2, 1 and 4 (each within the scatter of the next).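

Going by these compounds alone, the first step that can be tied to one structural change is methyl in place of fluoro on an aromatic carbon, para to a large group, and in this assay it reads a number 2.8 percentage points higher from compound 1 to compound 4 (within the scatter) as the printed result. At this position, then, 4-fluorophenyl and 4-methylphenyl cannot be told apart at the one concentration tested, and the swap of one single-atom substituent for the other gives no handle on the read-out. No measurement at hand bears on why these two groups read alike.

Still open, going by these compounds, is whether this ring position can move the number at all: compound 1 and compound 4 carry only fluoro and methyl there, and an amine, a carboxylic acid or a longer chain such as butyl on the same aromatic carbon would probe a far wider change. Within the data shown here, also open is whether the carbonyl of the aryl ketone matters to the read-out, a question that a step changing only that group, with the 4-fluorophenyl and the shared core kept, could answer.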